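Swapping the aryl group on sulfur in a diamino core

The source may report more compounds than this note shows. Statements on the series, on what has been measured and on what is new or still open speak of the compounds shown alone.

Of the compounds shown here, three sharing one core have been tested in a functional assay on SK-MEL-5 cells (Homo sapiens) for inhibition, read by sulforhodamine B assay, with a stated time of 48 h; on this read-out higher numbers stand for lower toxicity in this test and lower numbers for higher toxicity in this test. Compound 1 `Nc1cc(N)c2nc(-c3ccccc3)c(Oc3ccc(Cl)c(Cl)c3)nc2c1` gives 83200 nM in this assay. Compound 2 `Nc1cc(N)c2nc(-c3ccccc3)c(Sc3ccc(F)cc3)nc2c1` differs from compound 1 only in its aryl ether or thioether arm; in this assay compound 2 gives 70800 nM. Compound 3 `COc1cc(CNc2nc3cc(N)cc(N)c3nc2-c2ccccc2)cc(OC)c1OC`, carrying a benzylamine arm instead, gives 29500 nM. Among these, compound 2 holds the second highest number of the three; its nearest neighbour is compound 1, while the gap to compound 3 is beyond the scatter, so compound 3 is the more toxic of that pair in this test.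

Compound 4 `Nc1cc(N)c2nc(-c3ccccc3)c(Sc3ccc(Cl)c(Cl)c3)nc2c1` is not yet measured. It differs from compound 2 by 3,4-dichlorophenyl in place of 4-fluorophenyl on a sulfur. Going by the values given here, the one measured step that bears on this kind of change is a 1.2-fold lower number from compound 1 to compound 2 (0.07 log units; within the scatter), which also exchanged the aryl arm and moved the number very little. On that basis, the step from compound 2 to compound 4 in this assay is expected to stay within the scatter, with no clear direction, giving an expected 1.1-fold higher number from compound 2 to compound 4 (0.03 log units; within the scatter). Compound 4 is therefore estimated at 75000 nM, with a range from 35000 nM to 160000 nM.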

Compound 4, concentration lethal to 50% of the cells: < 100000 nM
Compound 4: a limit, no number; the forecaster's own chance of this, stated with the estimate: 10%; the middle value is on the limit's open side.
By their numbers in this assay, from the lowest: compound 3; then compounds 2 and 1 (each within the scatter of the next).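

In this assay compound 4 gives < 100000 nM, which is a limit and not a number. The steps from compound 1 and from compound 2 to compound 4 therefore cannot be read: the limit of < 100000 nM in this assay, at which 1 of the 4 values shown sits.

The compounds shown leave open whether 3,4-dichlorophenyl in place of 4-fluorophenyl on a sulfur shifts the number at all, and in which direction.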